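Swapping the aryl group on the tetrazole of compound 3

The source may report more compounds than this note shows. Statements on the series, on what has been measured and on what is new or still open speak of the compounds shown alone.

Among the measured compounds shown here, compound 3 `Cc1cc(NC(=O)Cn2nnc(-c3cccc(Cl)c3)n2)n(C2CCCCC2)n1` is the only member of this small set for which a number is reported in an assay on HEK293 cells for activation of Kir3.1/Kir3.2 (Homo sapiens), read by thallium flux; on this read-out lower numbers stand for an effect already at smaller amounts and higher numbers for an effect only at larger amounts of compound: compound 3 gives 300 nM. The other two entries offer no figure to rank it against. Compound 1 `Cc1cc(NC(=O)Cn2nnc(-c3ccccc3)n2)n(C2CCS(=O)(=O)CC2)n1` reaches only a limit of the assay, > 10000 nM, which places it at the limit of > 10000 nM in this assay, at which 1 of the 3 values shown sits. Compound 2 `O=C(Cn1nnc(-c2ccccc2)n1)Nc1cc(C2(C(F)(F)F)CC2)nn1C1CCCCC1` is recorded in this assay as "not active" (no number reported), without a number. For the measured compounds named here, compound 3 therefore stands alone as the single quantified point, with no measured step to any neighbour.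

Compound 4 `Cc1cc(NC(=O)Cn2nnc(-c3ccc(F)cc3)n2)n(C2CCCCC2)n1` differs from compound 3 in one place: 4-fluorophenyl in place of 3-chlorophenyl on an aromatic carbon. Going by the values given here, no measured pair in this set reports what such a swap does in this assay. Without a comparable step on record, the change is expected to cost a modest amount of potency, and the step from compound 3 to compound 4 is estimated as a 2.0-fold higher number from compound 3 to compound 4 (0.30 log units; within the scatter), a shift that could still fall within the usual scatter. Compound 4 is thus estimated at 600 nM, with a plausible range from 150 nM to 3000 nM.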

Compound 4, half-maximal effective concentration: 180 nM
Estimate against measurement, compound 4: 3.3-fold (0.52 log units) above; low and high end bracket the measured number.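

In this assay, the aryl group on the aromatic carbon of the five-membered aromatic ring with 4 nitrogen now has its first measured step, a 1.7-fold lower number from compound 3 to compound 4 (0.22 log units; within the scatter), so this place accepts either 3-chlorophenyl or 4-fluorophenyl with a number still reported. The two compounds cannot be ranked, and the swap changes the halogen and its place on the phenyl ring together, so the two changes cannot be told apart. Nothing on record here bears on why the two values lie so close.

Still open, going by these compounds, is whether 3-fluorophenyl or 4-chlorophenyl on the core of compound 3 would read the same, which would separate the halogen from its place. Also open, on these data alone, is whether a phenyl ring carrying an amine or a carboxylic acid would keep a number in this assay.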